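A few compounds are considered here, and "the series" means these few. Any claim that something is new, unique, unknown or untested is made for them only; others in the source may bear on it.

Measured so far:
compound 1, `CCCS(=O)(=O)Nc1ccc(F)c(C(=O)c2n[nH]c3ncc(-c4ccc(Cl)c(Cl)c4)cc23)c1F`: 45% in an assay for binding affinity to dual specificity mitogen-activated protein kinase kinase 4 (Homo sapiens), read by KINOMEscan, tested at 100 nM; on this read-out higher numbers stand for a weaker effect at the one concentration tested and lower numbers for a stronger effect
compound 2, `CCCS(=O)(=O)Nc1ccc(F)c(C(=O)c2n[nH]c3ncc(-c4ccc(C(C)(C)C)cc4)cc23)c1F`: 46% in this assay

Compound 2 carries the higher of the two numbers, yet the step of a number 1 percentage points higher from compound 1 to compound 2 (within the scatter) leaves it within the scatter of compound 1, so the two cannot be told apart on these data. Compound 3, `CCCS(=O)(=O)Nc1ccc(F)c(C(=O)c2n[nH]c3ncc(-c4ccc(-c5nnn[nH]5)cc4)cc23)c1F`, is not yet measured in this assay. Against compound 2 the change is 1H-tetrazol-5-yl in place of tert-butyl on an aromatic carbon. Within the data shown here, the single measured step, a number 1 percentage points higher from compound 1 to compound 2 (within the scatter), concerns the same aromatic carbon and stayed within the scatter, but it swaps one group for another of quite different make-up from the tetrazolyl, so it gives no direct guide here. Among the measured compounds shown here, no measured step tests a group of this kind; the range is set wide accordingly. Compound 3 is expected to give about 55% in this assay, between 30% and 85%. This means an expected step of a number 9 percentage points higher from compound 2 to compound 3 (within the scatter), not beyond the scatter.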

Compound 3, a percentage reported as activity, at one concentration (the size of the read-out at that concentration, not a potency): 0.15%
Compound 3: middle estimate off by 54.9 percentage points, on the high side; measured number below the stated range.
By their numbers in this assay, from the lowest: compound 3; then compounds 1 and 2 (each within the scatter of the next).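

In this assay this position is clearly not indifferent to what it carries: 1H-tetrazol-5-yl in place of tert-butyl gives a number 45.9 percentage points lower from compound 2 to compound 3 (beyond the scatter), and the comparison with the 3,4-dichlorophenyl compound gives a number 44.9 percentage points lower from compound 1 to compound 3 (beyond the scatter). Among these compounds, the earlier change at the same aromatic carbon, a number 1 percentage points higher from compound 1 to compound 2 (within the scatter), showed no separation, so the 4-(1H-tetrazol-5-yl)phenyl group is the first in this set to move the read-out beyond the scatter. No measurement shown bears on the reason for this step.

From the compounds shown here alone, it remains open whether the tetrazole ring itself is required, or whether a carboxylic acid or a primary amide on the same aromatic carbon would give a similarly low number. The compounds shown also leave open whether a 1H-tetrazol-5-yl group placed elsewhere on the phenyl ring would retain the effect.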